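The source may hold more compounds than are shown below. What is called first, only, known or untested is meant among the compounds shown, and "the series" means these compounds.

Measured so far in a physicochemical assay for solubility, read by HPLC, with a stated time of 24 h; a lower number here means a less soluble compound, a higher number a more soluble compound:

Compound 1, `COC(=O)CC1CCN(C[C@H]2CN(c3ccc(-n4cc(-c5ccccn5)cn4)c(F)c3)C(=O)O2)CC1`, gives 92100 nM.
Compound 2, `O=C1O[C@@H](CN2CCC(O)CC2)CN1c1ccc(-n2cc(-c3ccccn3)cn2)c(F)c1`, gives 45900 nM.
Compound 3, `O=C1CSC(=O)N1C[C@H]1CN(c2ccc(-n3cc(-c4ccccn4)cn3)c(F)c2)C(=O)O1`, gives 26900 nM.

Compound 3 stands at the lowest of the three numbers in this assay. Its gap to compound 2 lies within the scatter, so the two cannot be ordered, while the gap from compound 1, a 3.4-fold lower number from compound 1 to compound 3 (0.53 log units; beyond the scatter), is beyond it.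

The unmeasured compound 4, `O=C1O[C@@H](CSc2cccs2)CN1c1ccc(-n2cc(-c3ccccn3)cn2)c(F)c1`, differs from compound 3 in one place: (thiophen-2-yl)sulfanyl in place of 2,4-dioxo-1,3-thiazolidin-3-yl on a saturated chain carbon bound to a saturated ring carbon. Among the measured compounds shown here, no measured step makes a change of this kind. The two steps that touch the same position, a 3.4-fold lower number from compound 1 to compound 3 (0.53 log units; beyond the scatter) and a 1.7-fold lower number from compound 2 to compound 3 (0.23 log units; within the scatter), each exchanged a piperidin-1-yl group for the 2,4-dioxo-1,3-thiazolidin-3-yl group, and each moved the number down by a modest amount at most. Compound 4 now gives up that group as well, and with it the hydrogen-bond acceptors it carried, for a thiophene ring joined through sulfur. The number for compound 4 is expected to fall further, by a step of about a 4.5-fold lower number from compound 3 to compound 4 (0.65 log units; beyond the scatter), with compound 4 estimated at 6000 nM within a range from 1200 nM to 25000 nM.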

Compound 4, solubility: 8500 nM
For compound 4 the middle estimate is 1.4-fold (0.15 log units) below the measured one; the range from low to high includes it.
By their numbers in this assay, from the lowest: compound 4; then compounds 3, 2 and 1 (each within the scatter of the next, the first and the last beyond it).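

In this assay, the position on a saturated chain carbon bound to a saturated ring carbon still responds after the piperidine is gone: replacing 2,4-dioxo-1,3-thiazolidin-3-yl with (thiophen-2-yl)sulfanyl, which holds only carbon and sulfur, gives a 3.2-fold lower number from compound 3 to compound 4 (0.50 log units; beyond the scatter). Set against the two piperidine compounds, the same group gives a 5.4-fold lower number from compound 2 to compound 4 (0.73 log units; beyond the scatter) and an 11-fold lower number from compound 1 to compound 4 (1.03 log units; beyond the scatter), the only large step at this position so far, so the group placed here can move the number much further than the earlier compounds showed. No measurement in hand gives a reason for these steps.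

As far as these compounds go, compound 4 changes both the ring and its link, so it remains open whether the thiophene ring or the sulfur link goes with the lower number. A phenyl ring on the same sulfur would begin to separate the two, while a carboxylic acid or a primary amine at this position would show how far the number moves with quite different groups.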